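Piperazine amide variation in a spiro-hydantoin series

The source may report more compounds than this note shows. Statements on the series, on what has been measured and on what is new or still open speak of the compounds shown alone.

Measured compounds:
compound 1 `O=C(CN1CN(c2ccccc2)C2(CCN(C(=O)c3ccc(C4CCCCC4)cc3)CC2)C1=O)N1CCC(CO)CC1`: 1100 nM in an assay on HEK293 cells for displacement of a labelled ligand from NPC1-like intracellular cholesterol transporter 1 (Homo sapiens); a higher number here means a weaker inhibitor, a lower number a stronger inhibitor
compound 2 `CC(C)(C)OC(=O)N1CCN(C(=O)CN2CN(c3ccccc3)C3(CCN(C(=O)c4ccc(C5CCCCC5)cc4)CC3)C2=O)CC1`: 3500 nM

Compound 2 carries the higher of the two numbers; compound 1 sits lower by a gap beyond the usual scatter, so compound 2 is the weaker of the pair. Compound 3 `O=C(CN1CN(c2ccccc2)C2(CCN(C(=O)c3ccc(C4CCCCC4)cc3)CC2)C1=O)N1CCN(S(=O)(=O)c2ccccc2)CC1` differs from compound 2 by phenylsulfonyl in place of tert-butoxycarbonyl on an amine nitrogen in a ring. For the measured compounds named here, no measured pair shows this exchange, so no step can be read off directly. Going by the values given here, the only guide is that the group on the terminal amine of the shared core shifts the number between compound 1 and compound 2 by a modest amount, which suggests this position tolerates change without large swings. For compound 3 a small step in this assay is expected, more likely toward a lower number than a higher one, and not clearly beyond the scatter. The estimate corresponds to a 1.8-fold lower number from compound 2 to compound 3 (0.24 log units; within the scatter) in this assay. Compound 3 is therefore estimated at 2000 nM, with a range from 700 nM to 6000 nM.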

Compound 3, half-maximal inhibitory concentration: 14200 nM
Compound 3: middle estimate off by 7.1-fold (0.85 log units), on the low side; measured number outside the range, above it.
By their numbers in this assay, from the lowest: compound 1; then compound 2; then compound 3.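

In this assay, the group on the amine nitrogen of the six-membered ring with 2 nitrogen proves sensitive to exchange: phenylsulfonyl in place of tert-butoxycarbonyl gives a 4.1-fold higher number from compound 2 to compound 3 (0.61 log units; beyond the scatter), a step beyond the scatter and the only one in this set that isolates a change at this nitrogen. The number moves even though the leaving and entering groups have the same count of hydrogen-bond donors and acceptors and neither carries a net charge, so those counts alone do not set the value here. The entering group does differ in bringing sulfur and a six-membered aromatic ring of carbon only, but nothing measured on these compounds ties the step to either feature or to any other.

Still open, on these data alone, is whether the higher number goes with the sulfonyl link or with the phenyl ring, a question that methylsulfonyl or benzoyl on the same nitrogen would help to separate. Also open, as far as these compounds go, is how this nitrogen behaves with a simple acetyl group or as the free secondary amine, since both groups compared here are large and one step cannot define a trend.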